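Triazole Thioethers Staying Beyond the Cytotoxicity Limit

This account rests on a few compounds, and the source may have more. Where it says the series, first, only, none or still open, it means among the compounds named here.

Compound 3 `CCCc1nnc(SCC(=O)c2ccc(C)cc2)n1N1C(=O)c2ccccc2C1=O` carries a (4-methylphenyl)carbonyl group on a saturated chain carbon bound to a sulfur. In a functional assay on HepG2 cells (Homo sapiens) for cytotoxicity, read by MTT assay, with a stated time of 48 h (on this read-out lower numbers stand for stronger inhibition and higher numbers for weaker inhibition), compound 3 gives only a limit, > 200000 nM. Compound 1 `Cc1nnc(SCc2ccccc2Cl)n1N1C(=O)c2ccccc2C1=O` likewise reaches only the limit > 200000 nM. Compound 2 `CCCc1nnc(SCc2ccccc2)n1N1C(=O)c2ccccc2C1=O` also stops at the limit > 200000 nM. The step that the two limits leave unreadable from compound 2 to compound 3 thus cannot be read, since the limit of > 200000 nM in this assay, at which 3 of the 3 values shown sit, holds all three values. Compound 4 `CCCc1nnc(SCc2ccccc2Cl)n1N1C(=O)c2ccccc2C1=O` differs from compound 3 in that (2-chlorophenyl in place of (4-methylphenyl)carbonyl on a saturated chain carbon bound to a sulfur). This change brings together the groups of compound 1 and compound 2, whose values both sit at the limit. The step that the limit leaves unreadable from compound 3 to compound 4 is expected to stay within the scatter. Compound 4 is therefore estimated at about 300000 nM, within 150000 nM to 1000000 nM, most likely reported again as a limit.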

Compound 4, half-maximal inhibitory concentration: > 200000 nM
Compound 4: only a limit was reported; the forecaster's own chance of this, stated with the estimate: 90%; the middle value is on the limit's open side.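

Going by these compounds alone, compound 4 also gives only a limit, so no step linking it to compound 1, compound 2 or compound 3 can be read: the limit of > 200000 nM in this assay, at which 4 of the 4 values shown sit. The compounds shown leave open whether, in this assay, any change on the shared core gives a measurable value.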